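This account rests on a few compounds, and the source may have more. Where it says the series, first, only, none or still open, it means among the compounds named here.

In a functional assay on T47D cells (Homo sapiens) for cytotoxicity, read by CCK-8 assay (on this read-out higher numbers stand for weaker inhibition and lower numbers for stronger inhibition), three compounds built on one shared core have been tested, and none of them gave a readable number. Compound 1 `Oc1ccc(-c2cc(-c3ccsc3)cc(-c3ccccc3O)n2)cc1` gives > 50000 nM, which is a limit of the assay rather than a measured value. Compound 2 `Oc1ccccc1-c1cc(-c2ccoc2)cc(-c2ccccc2O)n1` likewise stops at a limit, > 50000 nM. Compound 3 `Oc1cccc(-c2cc(-c3ccoc3)cc(-c3ccccc3O)n2)c1` also sits at a limit, > 50000 nM. Within the data shown here, the only step between measured compounds that differ in one place, a step that the two limits leave unreadable from compound 2 to compound 3, therefore cannot be sized, since both of its ends rest at the limit described by the limit of > 50000 nM in this assay, at which 3 of the 3 values shown sit. Compound 4 `Oc1ccc(-c2cc(-c3ccoc3)cc(-c3ccccc3O)n2)cc1` differs from compound 3 in one place: 4-hydroxyphenyl in place of 3-hydroxyphenyl on an aromatic carbon. The same 4-hydroxyphenyl group is already present in compound 1, whose value is the same limit. With every shown value at the limit and no readable step to go on, no change beyond the scatter can be expected. Compound 4 is therefore expected to give 80000 nM, within 40000 nM to 200000 nM, most likely reported once more as a limit. The expected step that the limit leaves unreadable from compound 3 to compound 4 is accordingly one the assay is unlikely to resolve.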

Compound 4, half-maximal inhibitory concentration: > 50000 nM
Compound 4: only a limit was reported; the forecaster's own chance of this, stated with the estimate: 90%; the middle value does not contradict the limit.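

Compound 4 gives > 50000 nM and this is a limit. Its steps from compound 1, compound 2 and compound 3 therefore cannot be read: the limit of > 50000 nM in this assay, at which 4 of the 4 values shown sit. The compounds shown leave open whether 2-hydroxyphenyl, 3-hydroxyphenyl or 4-hydroxyphenyl, or furan-3-yl or thiophen-3-yl, makes any difference on the shared core.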